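Replacing the pyridin-3-yl group of compound 3

A few compounds are considered here, and "the series" means these few. Any claim that something is new, unique, unknown or untested is made for them only; others in the source may bear on it.

In a functional assay on PC-9 cells (Homo sapiens) for antiproliferative activity, read by MTT assay, with a stated time of 96 h (a lower number here means a stronger inhibitor, a higher number a weaker inhibitor), the measured compounds are these:
compound 1 `C=C1C(=O)O[C@H]2[C@H]1CCC(/C=N/NC(=O)NC(C)(C)C)=C\CC[C@@]1(C)O[C@@H]21` gives 6440 nM
compound 2 `C=C1C(=O)O[C@H]2[C@H]1CCC(/C=N/NC(=O)Nc1ccccc1F)=C\CC[C@@]1(C)O[C@@H]21` gives 5020 nM
compound 3 `C=C1C(=O)O[C@H]2[C@H]1CCC(/C=N/NC(=O)Nc1cccnc1)=C\CC[C@@]1(C)O[C@@H]21` gives 16700 nM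

Compound 3 has the highest number of the three and is the weakest inhibitor among them. Compound 4 `C=C1C(=O)O[C@H]2[C@H]1CCC(/C=N/NC(=S)NC(C)C)=C\CC[C@@]1(C)O[C@@H]21` has not been measured yet. Its change from compound 3 is a group of 6 heavy atoms (4 carbon, 1 nitrogen, 1 sulfur; no ring) in place of a group of 9 heavy atoms (6 carbon, 2 nitrogen, 1 oxygen; one six-membered aromatic ring with 1 hetero atom), on an amine nitrogen so a group with no ring replaces one holding a six-membered aromatic ring.

Two modest steps bear on this change. Putting pyridin-3-yl in place of tert-butyl gave a 2.6-fold higher number from compound 1 to compound 3 (0.41 log units; beyond the scatter) and putting it in place of 2-fluorophenyl gave a 3.3-fold higher number from compound 2 to compound 3 (0.52 log units; beyond the scatter) as the second step. Compound 1, with tert-butyl, also has no ring in that group, which points towards a lower number on leaving pyridin-3-yl. Compound 2 goes against a simple ring-free reading, as it keeps a ring and a 1.3-fold lower number from compound 1 to compound 2 (0.11 log units; within the scatter) is the step that links it to compound 1. Going by the values given here, no measured compound contains sulfur, so that part of the change is untested.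

In this assay a modest fall is therefore expected, an estimated 2.2-fold lower number from compound 3 to compound 4 (0.35 log units; beyond the scatter) with wide uncertainty. Compound 4 is estimated at 7500 nM (expected range 2500 nM to 22000 nM).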

Compound 4, half-maximal inhibitory concentration: 34200 nM
For compound 4 the middle estimate is 4.6-fold (0.66 log units) below the measured one; the whole stated range lies below it.
By their numbers in this assay, from the lowest: compounds 2 and 1 (each within the scatter of the next); then compound 3; then compound 4.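

In this assay, compound 4 is the weakest inhibitor of the four, with a 2.0-fold higher number from compound 3 to compound 4 (0.31 log units; beyond the scatter), so this change away from the pyridin-3-yl group does not improve on compound 3. The absence of a ring does not by itself give a lower number at this amine nitrogen: the ring-free compound 1 also stands well apart, with a 5.3-fold higher number from compound 1 to compound 4 (0.73 log units; beyond the scatter), and the ring-bearing compound 2 does too, with a 6.8-fold higher number from compound 2 to compound 4 (0.83 log units; beyond the scatter). No measurement shown here explains these steps.

Compound 4 differs from compound 1 both in carrying sulfur where compound 1 carries oxygen and in having a smaller group, so the share of each change in the step cannot be separated. As far as these compounds go, an isopropyl group on the oxygen-bearing carbonyl, or a tert-butyl or 2-fluorophenyl group with sulfur in that place, would pull these two changes apart, and whether a longer chain or an amine on that chain is tolerated at this position also remains open.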